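Series notes: chloro in place of methyl, compound 4

The compounds below may be only part of what the source reports. "The series", "measured", "known", "first", "only" and "open" are said of these compounds alone.

Three compounds of the shared core have numbers in a functional assay on HT-29 cells (Homo sapiens) for cytotoxicity, read by MTT assay, with a stated time of 24 h; on this read-out lower numbers stand for stronger inhibition and higher numbers for weaker inhibition. Compound 1 `Cc1ncc([N+](=O)[O-])n1CCOc1ccc(F)cc1` gives 102 ug/mL. Compound 2 `Cc1ncc([N+](=O)[O-])n1CCOc1ccc(Cl)c(Cl)c1` gives 109 ug/mL. Among the compounds with values here, compound 3 `Cc1cc(OCCn2c([N+](=O)[O-])cnc2C)ccc1F` gives 140 ug/mL, a number that sits within the scatter of both other compounds; the one measured step leading to it is a 1.4-fold higher number from compound 1 to compound 3 (0.14 log units; within the scatter), also within the scatter.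

Compound 4 `Cc1ncc([N+](=O)[O-])n1CCOc1ccc(F)c(Cl)c1` differs from compound 3 by chloro in place of methyl on an aromatic carbon. Within the data shown here, no measured step swaps chloro for methyl on this ring. Compound 2 carries two chloro groups and no methyl, and its number lies close to that of compound 3. Compound 1 carries hydrogen in place of the methyl, and the step of a 1.4-fold higher number from compound 1 to compound 3 (0.14 log units; within the scatter) stayed within the scatter. All three measured numbers lie within the scatter of one another, so no movement beyond the scatter is expected in this assay. The expected step is a 1.2-fold lower number from compound 3 to compound 4 (0.09 log units; within the scatter). For compound 4 the estimate is 115 ug/mL, with a range from 70 ug/mL to 190 ug/mL.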

Compound 4, half-maximal inhibitory concentration: 199 ug/mL
For compound 4 the middle estimate is 1.7-fold (0.24 log units) below the measured one; measured number above the stated range.
By their numbers in this assay, from the lowest: compounds 1, 2, 3 and 4 (each within the scatter of the next).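

Across hydrogen, methyl and chloro at this position on the ring, with the fluoro group kept, this assay shows a 1.4-fold higher number from compound 3 to compound 4 (0.15 log units; within the scatter) for chloro in place of methyl and a 2.0-fold higher number from compound 1 to compound 4 (0.29 log units; within the scatter) for chloro in place of hydrogen. With chloro kept at this position, fluoro in place of chloro on the neighbouring substituted carbon gives a 1.8-fold higher number from compound 2 to compound 4 (0.26 log units; within the scatter) and so also stays within the scatter, which means none of these single replacements separates from the others on this read-out. No measurement at hand bears on an explanation for these numbers.

As far as these compounds go, whether a hydroxyl, an amine or a carboxylic acid at this position would give a step beyond the scatter remains open. Equally open, from the compounds shown here alone, is whether a change in the chain joining the ring to the shared core would move the number more than these ring replacements do.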